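Chloro placement on the aryl imine and P388 cytotoxicity

This account rests on a few compounds, and the source may have more. Where it says the series, first, only, none or still open, it means among the compounds named here.

Compound 3 `Cc1c(/N=C/c2ccc(Cl)cc2Cl)c(=O)n(-c2ccccc2)n1C` carries a 2,4-dichlorophenyl group on the carbon with a double bond to nitrogen. In a functional assay on P388 cells (Mus musculus) for cytotoxicity, read by MTT assay, with a stated time of 72 h (on this read-out higher numbers stand for weaker inhibition and lower numbers for stronger inhibition), compound 3 gives 363000000 nM, the highest of the three numbers, though its companions lie close: compound 1 `Cc1c(/N=C/c2ccccc2Cl)c(=O)n(-c2ccccc2)n1C` gives 324000000 nM and compound 2 `COc1ccccc1/C=N/c1c(C)n(C)n(-c2ccccc2)c1=O` gives 229000000 nM. The steps among them are small: a 1.1-fold higher number from compound 1 to compound 3 (0.05 log units; within the scatter), a 1.4-fold lower number from compound 1 to compound 2 (0.15 log units; within the scatter) and a 1.6-fold higher number from compound 2 to compound 3 (0.20 log units; within the scatter), each within the scatter.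

Compound 4 `Cc1c(/N=C/c2cccc(Cl)c2)c(=O)n(-c2ccccc2)n1C` differs from compound 3 by 3-chlorophenyl in place of 2,4-dichlorophenyl on a carbon with a double bond to nitrogen. For the measured compounds named here, no measured pair makes exactly this change, but the nearest steps, chloro in place of hydrogen on an aromatic carbon and methoxy in place of chloro on an aromatic carbon, shifted this assay by no more than the scatter. Compound 4 is therefore expected to show a step of a 1.1-fold lower number from compound 3 to compound 4 (0.04 log units; within the scatter) from compound 3, with no movement beyond the scatter. The estimate for compound 4 in this assay is 330000000 nM, with a range from 180000000 nM to 600000000 nM.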

Compound 4, half-maximal inhibitory concentration: 550000000 nM
For compound 4 the middle estimate is 1.7-fold (0.22 log units) below the measured one, within the range that was stated.
By their numbers in this assay, from the lowest: compounds 2, 1, 3 and 4 (each within the scatter of the next, the first and the last beyond it).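

In this assay, for the compounds shown here, the set now holds its only step beyond the scatter, a modest one: 3-chlorophenyl in place of 2-methoxyphenyl on the carbon with a double bond to nitrogen gives a 2.4-fold higher number from compound 2 to compound 4 (0.38 log units; beyond the scatter) on this read-out. The chloro-bearing groups stay unresolved from one another, since 3-chlorophenyl in place of 2,4-dichlorophenyl gives a 1.5-fold higher number from compound 3 to compound 4 (0.18 log units; within the scatter) and 3-chlorophenyl in place of 2-chlorophenyl gives a 1.7-fold higher number from compound 1 to compound 4 (0.23 log units; within the scatter) within this set. Going by these compounds alone, no measurement offers an explanation for the one step that exceeds the scatter.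

The compounds shown leave open whether an amine or a carboxylic acid on this aryl group would move the number further than chloro or methoxy does. They also leave open what a longer chain on the shared core would do.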